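The source may hold more compounds than are shown below. What is called first, only, known or untested is meant among the compounds shown, and "the series" means these compounds.

Measured so far: compound 1 `CCCCCCCOC(=O)CCC(=O)N1CCN(CCCOc2cc3c(Nc4ccc(F)c(Cl)c4)ncnc3cc2OC)CC1` gives 27.2% in a functional assay on A549 cells (Homo sapiens) for cytotoxicity, read by MTT assay, with a stated time of 24 h, tested at 80 uM (on this read-out higher numbers stand for a weaker effect at the one concentration tested and lower numbers for a stronger effect), and compound 2 `CCCCCCCCCCCCCCCCCOC(=O)CCC(=O)N1CCN(CCCOc2cc3c(Nc4ccc(F)c(Cl)c4)ncnc3cc2OC)CC1` gives 83.2% in this assay.

Compound 2 stands highest of the two numbers; its nearest neighbour is compound 1, and the step of a number 56 percentage points higher from compound 1 to compound 2 (beyond the scatter) is beyond the scatter.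

Compound 3 `CCCCCCCCCCCCCCCCCCOC(=O)CCC(=O)N1CCN(CCCOc2cc3c(Nc4ccc(F)c(Cl)c4)ncnc3cc2OC)CC1` is not yet measured in this assay. It differs from compound 2 by methyl in place of hydrogen on a saturated chain carbon, ten or more bonds along the chain from an oxygen next to a carbonyl group.

Among the measured compounds shown here, the only step that bears on this is a number 56 percentage points higher from compound 1 to compound 2 (beyond the scatter), where a decyl entered in place of hydrogen on the saturated chain. The change to compound 3 adds a single methyl at the far end of that chain, a far smaller change in the same direction. A step in this assay of at most a few points higher, within the scatter, is therefore expected for compound 3, as a number 2.8 percentage points higher from compound 2 to compound 3 (within the scatter).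

Compound 3 is estimated at 86% in this assay, with a range of 72% to 97%.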

Compound 3, a percentage reported as activity, at one concentration (the size of the read-out at that concentration, not a potency): 86.7%
Compound 3: the middle estimate sits 0.7 percentage points below what was measured; low and high end bracket the measured number.
By their numbers in this assay, from the lowest: compound 1; then compounds 2 and 3 (each within the scatter of the next).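

In this assay, methyl in place of hydrogen on a saturated chain carbon, ten or more bonds along the chain from an oxygen next to a carbonyl group, gives a number 3.5 percentage points higher from compound 2 to compound 3 (within the scatter) and does not separate the two compounds at this position. Undecyl in place of hydrogen, seven bonds along the chain from the same oxygen, gives a number 59.5 percentage points higher from compound 1 to compound 3 (beyond the scatter) and matches the large size of a number 56 percentage points higher from compound 1 to compound 2 (beyond the scatter), so among the three compounds only compound 1 stands apart. No measurement shown gives a reason for this pattern.

Chains of a length between those of compound 1 and compound 2 remain open, as does a still longer chain than that of compound 3 in this assay. Also open, from the compounds shown here alone, is how an amine or a carboxylic acid carried on the chain would read.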